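This account rests on a few compounds, and the source may have more. Where it says the series, first, only, none or still open, it means among the compounds named here.

In a functional assay on HT-29 cells (Homo sapiens) for inhibition, read by MTT assay, with a stated time of 48 h (a lower number here means a stronger inhibitor, a higher number a weaker inhibitor), compound 3 `COc1cc(-c2nnc(SCc3ccccc3)n2-c2ccc(N(C)C)cc2)cc(OC)c1OC` gives > 60000 nM, which is a limit and not a number. Its parent thiol, compound 2 `COc1cc(-c2nnc(S)n2-c2ccc(N(C)C)cc2)cc(OC)c1OC`, gives > 60000 nM, also a limit. Among the compounds with values here, the only measured step here is a step that the two limits leave unreadable from compound 2 to compound 3, so no size can be taken from it. Compound 3 therefore has no exact place in the series, and (the limit of > 60000 nM in this assay, at which 3 of the 3 values shown sit).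

Compound 4 `COc1cc(-c2nnc(SCc3ccc(C)cc3)n2-c2ccc(N(C)C)cc2)cc(OC)c1OC` differs from compound 3 by methyl in place of hydrogen on an aromatic carbon, turning benzylsulfanyl into (4-methylbenzyl)sulfanyl. The closest guide is compound 1 `COc1ccc(-n2c(SCc3ccc(C)cc3)nnc2-c2cc(OC)c(OC)c(OC)c2)cc1`, which already carries that group on a core with a different aryl substituent. Compound 1 gives > 60000 nM, again a limit. Within the data shown here, no measured step shows this methyl raising potency, so no readable change is expected, and a report of the same limit is the likeliest outcome. The expected step is an at least 1.2-fold lower number from compound 3 to compound 4 (0.07 log units; that floor lies within the scatter). For compound 4 the estimated value is 50000 nM, with an expected range from 10000 nM to 120000 nM.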

Compound 4, half-maximal inhibitory concentration: 27500 nM
Beside the measured number, compound 4's estimate is 1.8-fold (0.26 log units) above it; the measured number falls inside the stated range.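

Turning benzylsulfanyl into (4-methylbenzyl)sulfanyl gives an at least 2.1-fold lower number from compound 3 to compound 4 (0.33 log units; beyond the scatter), so this aromatic carbon, para to a large group, is the first place in the series where a change can be read in this assay. Measured from the thiol, 4-methylbenzyl on the sulfur gives an at least 2.1-fold lower number from compound 2 to compound 4 (0.33 log units; beyond the scatter), whereas the step to plain benzyl could not be read. The methyl does not act alone, as compound 1 carries the same 4-methylbenzyl group, and dimethylamino in place of methoxy gives an at least 2.1-fold lower number from compound 1 to compound 4 (0.33 log units; beyond the scatter), leaving compound 4 the only compound shown with a readable value: the limit of > 60000 nM in this assay, at which 3 of the 4 values shown sit.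

On these data alone, these steps give only minimum sizes, and the true gaps remain unknown. As far as these compounds go, whether an ethyl group or a chlorine atom on the same aromatic carbon would carry the change further stays open.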